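The source may hold more compounds than are shown below. What is called first, only, known or untested is meant among the compounds shown, and "the series" means these compounds.

Measured so far in a physicochemical assay for lipophilicity, at pH 7.4; on this read-out lower numbers stand for lower lipophilicity and higher numbers for higher lipophilicity:

Compound 1 `CNC(=O)c1cc(C(=O)NC2CCC2)cn(Cc2ccncc2)c1=O` gives 1.7
Compound 2 `CNC(=O)c1cc(C(=O)NC2CC2)cn(Cc2cccc(OC)c2)c1=O` gives 3
Compound 3 `CNC(=O)c1cc(C(=O)NCCO)cn(Cc2ccccc2)c1=O` gives 1.9

Compound 2 stands highest of the three numbers in this assay. Its nearest neighbour is compound 3, which reads lower by a gap beyond the scatter, and the furthest is compound 1, lower by a still larger gap, also beyond the scatter. For the measured compounds named here, no two of the three measured compounds differ in only one place, so no single step within the measured set is available to lean on.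

Compound 4 `CNC(=O)c1cc(C(=O)NC2CC2)cn(Cc2cccc3[nH]ccc23)c1=O` is not yet measured. Compared with compound 2 the change is 1H-indol-4-yl in place of 3-methoxyphenyl on a saturated chain carbon bound to an aromatic nitrogen. Going by the values given here, the measured series holds no precedent for this exchange, so the expectation rests on the size of the groups counted there, which are close in heavy-atom count. The step expected from compound 2 to compound 4 in this assay is a number 0.10 log units lower from compound 2 to compound 4 (within the scatter), which is not expected to exceed the scatter in either direction. Compound 4 is therefore estimated at 2.9, within a range from 2.4 to 3.4.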

Compound 4, distribution coefficient: 2.9
The estimate for compound 4 equals the measured number at the digits printed; the measured number falls inside the stated range.
By their numbers in this assay, from the lowest: compounds 1 and 3 (each within the scatter of the next); then compounds 4 and 2 (each within the scatter of the next).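

For the compounds shown here, on a saturated chain carbon bound to an aromatic nitrogen, the exchange of 3-methoxyphenyl for 1H-indol-4-yl gives the first single-place step: in this assay, the step is a number 0.10 log units lower from compound 2 to compound 4 (within the scatter). Going by these compounds alone, the entering group brings a five-membered aromatic ring and a hydrogen-bond donor and the leaving group takes away a hydrogen-bond acceptor, yet the read-out stays within the scatter for this pair, which is all that can be said of this place so far. Nothing measured here bears on the reason for this result.

The compounds shown leave open how a carboxylic acid or a primary amine at this place would read in this assay. They also leave open whether the same exchange gives a similar step with a different amide on the shared core, as this is a single pair.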